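This account rests on a few compounds, and the source may have more. Where it says the series, first, only, none or still open, it means among the compounds named here.

Compound 1 (`Cc1c2c(n3c1CCN(C(=O)CN)C[C@@H](C)[C@H](C)Nc1cc-3ccc1C(N)=O)CC(C)(C)CC2=O`) gives 378 nM
Compound 2 (`COCCC(=O)N1CCCc2c(C)c3c(n2-c2ccc(C(N)=O)c(c2)N[C@@H](C)[C@@H]1C)CC(C)(C)CC3=O`) gives 80 nM

In a functional assay on U-87MG ATCC cells (Homo sapiens) for antiproliferative activity (a higher number here means a weaker inhibitor, a lower number a stronger inhibitor), compound 1 stands at 378 nM as the higher of the two numbers, and compound 2 lies lower at 80 nM on the same scale. Compound 3 (`Cc1c2c(n3c1CCN(C(=O)C1(N)CCCC1)C[C@@H](C)[C@H](C)Nc1cc-3ccc1C(N)=O)CC(C)(C)CC2=O`) keeps the core of compound 1 and carries 1-aminocyclopentyl in place of aminomethyl on a carbonyl carbon. For the measured compounds named here, no measured pair isolates this change, so the data give no direct guide to its size. A modest step toward a lower number in this assay is expected, perhaps no larger than the scatter, and compound 2 at 80 nM shows only that a lower number occurs among these compounds. The expected step (a 1.9-fold lower number from compound 1 to compound 3 (0.28 log units; within the scatter)) is therefore small. For compound 3 the estimated value is 200 nM (expected range 70 nM to 600 nM).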

Compound 3, half-maximal inhibitory concentration: 44 nM
Beside the measured number, compound 3's estimate is 4.5-fold (0.66 log units) above it; measured number outside the range, below it.
By their numbers in this assay, from the lowest: compounds 3 and 2 (each within the scatter of the next); then compound 1.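

In this assay, for the compounds shown here, the exchange of aminomethyl for 1-aminocyclopentyl on a carbonyl carbon gives an 8.6-fold lower number from compound 1 to compound 3 (0.93 log units; beyond the scatter) and is the only step here that isolates one change. It shows that this place, where the carbonyl carbon's other neighbour is an amide-type nitrogen in a ring, accepts the larger group, and that the number moves beyond the scatter although both groups have the same count of hydrogen-bond donors and acceptors. No measurement shown here accounts for the size of this step.

As far as these compounds go, what remains open is whether the five-membered ring itself matters or only the substitution on the carbon that holds the amine. A 1-aminocyclohexyl group, a 1-aminocyclopropyl group or an open-chain 2-aminopropan-2-yl group at this place would help to separate the two.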